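Moving the chlorine on the benzyl group of compound 2

The source may report more compounds than this note shows. Statements on the series, on what has been measured and on what is new or still open speak of the compounds shown alone.

Measured so far:
compound 1 `COc1ccc(Nc2nc(SCc3cn(Cc4ccccc4Cl)nn3)nc(-c3ccccc3)c2C#N)cc1` — 7960 nM
compound 2 `N#Cc1c(Nc2ccccc2F)nc(SCc2cn(Cc3ccccc3Cl)nn2)nc1-c1ccccc1` — 23000 nM
compound 3 `Cc1ccccc1Nc1nc(SCc2cn(Cc3ccccc3Cl)nn2)nc(-c2ccccc2)c1C#N` — 9740 nM

In a functional assay on ECa-109 cells (Homo sapiens) for inhibition, read by MTT assay, with a stated time of 72 h (a higher number here means a weaker inhibitor, a lower number a stronger inhibitor), compound 2 gives the highest number of the three. The nearest is compound 3 with a 2.4-fold lower number from compound 2 to compound 3 (0.37 log units; beyond the scatter), and the furthest is compound 1, seen in the other direction as a 2.9-fold higher number from compound 1 to compound 2 (0.46 log units; beyond the scatter). Compound 1 and compound 3 sit close together, as a 1.2-fold higher number from compound 1 to compound 3 (0.09 log units; within the scatter) shows.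

Compound 4 `N#Cc1c(Nc2ccccc2F)nc(SCc2cn(Cc3ccc(Cl)cc3)nn2)nc1-c1ccccc1` differs from compound 2 in one place: 4-chlorophenyl in place of 2-chlorophenyl on a saturated chain carbon bound to an aromatic nitrogen. The measured steps all vary the ring on the nitrogen attached to the shared core; none of them touches the chlorobenzyl group, so none bears directly on this change. With no step to lean on, there is no reason from the numbers to expect a move in this assay beyond the scatter in either direction, though the uncertainty is wider than for a change that had been sampled. Compound 4 is therefore expected to stay close to compound 2, with no change at the digits printed from compound 2 to compound 4 (within the scatter) as the estimated step. The estimate for compound 4 in this assay is 23000 nM, within a range from 8000 nM to 65000 nM.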

Compound 4, half-maximal inhibitory concentration: > 64000 nM
Compound 4 was reported as a limit (the forecaster's own chance of this, stated with the estimate: 10%); middle value at least 2.7-fold (0.44 log units) away from the limit.
By their numbers in this assay, from the lowest: compounds 1 and 3 (each within the scatter of the next); then compound 2. At a limit, above all of these: compound 4.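

In this assay, the group on the saturated chain carbon bound to an aromatic nitrogen turns out to affect the read-out: replacing 2-chlorobenzyl with 4-chlorobenzyl gives an at least 2.7-fold higher number from compound 2 to compound 4 (0.44 log units; beyond the scatter). Among these compounds, the earlier compounds varied only the ring on the nitrogen attached to the shared core, so this is the first evidence that moving the chlorine within the benzyl group, with the same atoms joined differently, can yield a weaker inhibitor. Compound 4 is reported only as a limit: the limit of > 64000 nM in this assay, at which 1 of the 4 values shown sits.

The compounds shown leave open whether 4-chlorobenzyl would have the same effect alongside the 4-methoxyphenyl of compound 1 or the 2-methylphenyl of compound 3, since the comparison here rests on a single pair carrying 2-fluorophenyl. They also leave open how a benzyl group with no chlorine, or a longer chain ending in a phenyl ring, would compare with the 2-chlorobenzyl of compound 2 at this same place.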